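Bromo for fluoro on an already inactive urea

A few compounds are considered here, and "the series" means these few. Any claim that something is new, unique, unknown or untested is made for them only; others in the source may bear on it.

Compound 2 `CC1(C)CC(NC(=O)Nc2ccccc2Cl)c2cc(F)ccc2O1` reaches only a limit, > 30000 nM, in a functional assay (aorta) with Rattus norvegicus as the target; a lower number here means that less compound is needed, a higher number that more compound is needed for the effect. Compound 1 `Cc1cccc(NC(=O)NC2CC(C)(C)Oc3ccc(Br)cc32)c1` likewise shows only a limit, > 10000 nM, in this assay. Going by the values given here, no step between measured compounds is available, so compound 2 stands simply at its limit. Compound 3 `CC1(C)CC(NC(=O)Nc2ccccc2Cl)c2cc(Br)ccc2O1` differs from compound 2 by bromo in place of fluoro on an aromatic carbon. Compound 1 already carries bromo and sits at the limit of > 10000 nM in this assay, at which 1 of the 2 values shown sits, which gives no sign of a gain. The step from compound 2 to compound 3 is therefore expected to be none beyond the scatter, a number no higher from compound 2 to compound 3 (the limit leaves the size open). For compound 3 the estimate is 30000 nM, between 10000 nM and 100000 nM.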

Compound 3, half-maximal effective concentration: > 30000 nM
Compound 3: a limit, no number; the forecaster's own chance of this, stated with the estimate: 85%; the middle value sits exactly at the limit.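

In this assay compound 3 gives > 30000 nM, which is a limit and not a number. Going by these compounds alone, compound 1 and compound 2 also stand at limits, so no step to compound 3 can be read. The compounds shown leave open how bromo and fluoro compare on the shared core.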